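Trifluoromethyl for Methyl on a Diaryl Urea

The source may hold more compounds than are shown below. What is called first, only, known or untested is meant among the compounds shown, and "the series" means these compounds.

Measured so far:
Compound 1 `COc1cc2cc(Oc3ccc(NC(=O)Nc4ccccc4)cc3)c(C)nc2cc1OC` gives 89.4% in a functional assay on MDA-MB-435 cells (Homo sapiens) for inhibition, read by sulforhodamine B assay, with a stated time of 48 h, tested at 10 uM; on this read-out higher numbers stand for a weaker effect at the one concentration tested and lower numbers for a stronger effect.
Compound 2 `COc1cc2cc(Oc3ccc(NC(=O)Nc4ccc(C)cc4)cc3)c(C)nc2cc1OC` gives 107% in this assay.

For the measured compounds named here, of these two numbers, that of compound 2 is the higher, meaning the weaker effect at the single concentration tested; the only measured step, a number 17.6 percentage points higher from compound 1 to compound 2 (beyond the scatter), runs between the two and is described as modest, though beyond the scatter.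

Compound 3 `COc1cc2cc(Oc3ccc(NC(=O)Nc4ccc(C(F)(F)F)cc4)cc3)c(C)nc2cc1OC` has not yet been measured. It differs from compound 2 by trifluoromethyl in place of methyl on an aromatic carbon. Going by the values given here, the one measured step, a number 17.6 percentage points higher from compound 1 to compound 2 (beyond the scatter), concerns a different change, methyl in place of hydrogen, so it bears on the new step only loosely: it shows that a small group at this position shifts the number modestly, but says nothing about exchanging methyl for trifluoromethyl. With so little to go on, compound 3 is expected to show no step beyond the scatter in this assay, that is a number 7 percentage points lower from compound 2 to compound 3 (within the scatter). The estimate for compound 3 is 100%, with a range from 75% to 120%.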

Compound 3, a percentage reported as activity, at one concentration (the size of the read-out at that concentration, not a potency): 80.3%
Beside the measured number, compound 3's estimate is 19.7 percentage points above it; the range from low to high includes it.
By their numbers in this assay, from the lowest: compounds 3 and 1 (each within the scatter of the next); then compound 2.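

In this assay, this position responds to which group sits on it, not merely to whether a group is there: trifluoromethyl in place of methyl gives a number 26.7 percentage points lower from compound 2 to compound 3 (beyond the scatter), a shift beyond the scatter and opposite in direction to the earlier methyl step, a number 17.6 percentage points higher from compound 1 to compound 2 (beyond the scatter). Set against the hydrogen of the unsubstituted compound, trifluoromethyl gives a number 9.1 percentage points lower from compound 1 to compound 3 (within the scatter), which is within the scatter, so among these three compounds only the methyl of compound 2 stands apart, with the weaker effect at the single concentration tested. Nothing available here explains why two groups of such similar placement part in this way.

The compounds shown leave open how other groups would behave at this position, such as an amine, a carboxylic acid, a chlorine atom or a longer chain, and so whether methyl is an isolated case or part of a wider trend. They also leave open whether the same exchange of methyl for trifluoromethyl would give a similar step at another carbon of this ring or on a different core.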